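Working notes: the benzyl ether group, compound 2 to compound 4

The source may hold more compounds than are shown below. What is called first, only, known or untested is meant among the compounds shown, and "the series" means these compounds.

Measured so far:
compound 1 `Cc1cc(C(=O)O)nn1Cc1cc(Br)ccc1OCc1ccc(Cl)cc1Cl`: 0.132 nM
compound 2 `Cc1cc(C(=O)O)nn1Cc1cc(Br)ccc1OCc1ccc(Cl)cc1`: 8.71 nM
compound 3 `Cc1cc(C(=O)O)nn1Cc1cc(Br)ccc1OCc1ccc(C(F)(F)F)cc1`: 35.5 nM

In an assay on CHO-K1 cells for displacement of a labelled ligand from prostaglandin E2 receptor EP1 subtype (Homo sapiens) (a lower number here means a stronger inhibitor, a higher number a weaker inhibitor), compound 2 gives 8.71 nM, the second highest of the three numbers: compound 3 lies nearest, compound 1 furthest. Compound 4 `Cc1cc(C(=O)O)nn1Cc1cc(Br)ccc1OCc1cccc(Br)c1` differs from compound 2 by 3-bromophenyl in place of 4-chlorophenyl on a saturated chain carbon bound to an oxygen on an aromatic ring. Both measured steps also alter this benzyl ether group and so bear on the change, though neither matches it: the step of a 66-fold higher number from compound 1 to compound 2 (1.82 log units; beyond the scatter) was large, the step of a 4.1-fold higher number from compound 2 to compound 3 (0.61 log units; beyond the scatter) modest. Exchanging one halogenated phenyl for another is closest in kind to the modest step, so a modest step in this assay, most likely toward a higher number, is expected; the direction is uncertain. Compound 4 is therefore estimated at 15 nM, between 3 nM and 80 nM, meaning an expected step of a 1.7-fold higher number from compound 2 to compound 4 (0.24 log units; within the scatter).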

Compound 4, half-maximal inhibitory concentration: 17.8 nM
For compound 4 the middle estimate is 1.2-fold (0.07 log units) below the measured one; low and high end bracket the measured number.
By their numbers in this assay, from the lowest: compound 1; then compound 2; then compounds 4 and 3 (each within the scatter of the next).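

In this assay, exchanging 4-chlorophenyl for 3-bromophenyl gives a 2.0-fold higher number from compound 2 to compound 4 (0.31 log units; beyond the scatter), so this position tolerates a change of both halogen and ring placement with only a modest shift. Exchanging 2,4-dichlorophenyl for 3-bromophenyl gives a 130-fold higher number from compound 1 to compound 4 (2.13 log units; beyond the scatter), and among the compounds shown, only compound 1 with its 2,4-dichlorophenyl group stands apart. Nothing available explains these differences.

Going by these compounds, this step changes halogen and placement together, so their separate contributions remain open. Also open, on these data alone, is how a methoxy group or a nitrile on this phenyl ring would read.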